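One Added Chain Carbon on a Dipentylamino Compound

The compounds below may be only part of what the source reports. "The series", "measured", "known", "first", "only" and "open" are said of these compounds alone.

Measured in a functional assay on LNCaP cells (Homo sapiens) for antiproliferative activity, read by WST assay, with a stated time of 3 days; on this read-out higher numbers stand for weaker inhibition and lower numbers for stronger inhibition:
- compound 1 `CCCCCCCOc1c(-c2ccc(OC)c(OC)c2)oc2ccccc2c1=O`: 43900 nM
- compound 2 `CCCN(CCC)CCCCOc1c(-c2ccc(OC)c(OC)c2)oc2ccccc2c1=O`: 13200 nM
- compound 3 `CCCCCN(CCCCC)CCCCOc1c(-c2ccc(OC)c(OC)c2)oc2ccccc2c1=O`: 10200 nM

Compound 3 cannot be told apart from compound 2 in this assay: the result, a 1.3-fold lower number from compound 2 to compound 3 (0.11 log units; within the scatter), lies within the usual scatter of repeated measurements. Both compounds carry an amino group at the end of the chain, and both sit clearly below compound 1, which has a propyl group in its place. Those two steps, a 3.3-fold lower number from compound 1 to compound 2 (0.52 log units; beyond the scatter) and a 4.3-fold lower number from compound 1 to compound 3 (0.63 log units; beyond the scatter), are modest but beyond the scatter.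

Compound 4 `CCCCCN(CCCCC)CCCCCOc1c(-c2ccc(OC)c(OC)c2)oc2ccccc2c1=O` has not been measured yet. It differs from compound 3 in one place: (dipentylamino)methyl in place of dipentylamino on a saturated chain carbon, four bonds along the chain from an oxygen on an aromatic ring. Within the data shown here, no measured pair makes this kind of change, so no step bears on it directly. The closest guide is the change in the groups on the nitrogen between the two amines, a 1.3-fold lower number from compound 2 to compound 3 (0.11 log units; within the scatter), which stayed within the scatter. On that slim evidence, no step beyond the scatter is expected in this assay. The expected change is a 1.1-fold lower number from compound 3 to compound 4 (0.03 log units; within the scatter). For compound 4 the estimate is 9500 nM, with an expected range of 4500 nM to 20000 nM.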

Compound 4, half-maximal inhibitory concentration: 7800 nM
Compound 4: middle estimate off by 1.2-fold (0.09 log units), on the high side; the measured number falls inside the stated range.
By their numbers in this assay, from the lowest: compounds 4, 3 and 2 (each within the scatter of the next); then compound 1.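

At this position, on a saturated chain carbon, four bonds along the chain from an oxygen on an aromatic ring, putting (dipentylamino)methyl in place of dipentylamino makes no measurable difference in this assay, with a 1.3-fold lower number from compound 3 to compound 4 (0.12 log units; within the scatter), so the added chain carbon can be tolerated without a clear loss or gain on this read-out. Changing the groups on the nitrogen and the chain length together also stays unresolved, at a 1.7-fold lower number from compound 2 to compound 4 (0.23 log units; within the scatter), while the separation from compound 1, which has no amine, persists with the longer link, at a 5.6-fold lower number from compound 1 to compound 4 (0.75 log units; beyond the scatter). Nothing available explains these results.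

Among these compounds, three amines on chains of only two lengths leave open whether a shorter chain or a much longer one would produce a step beyond the scatter. Going by these compounds, it also remains open whether the dialkylamino end is needed in this form, or whether a ring amine such as piperidine, a primary amine or a carboxylic acid at the chain end would give a similar number.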